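The source may hold more compounds than are shown below. What is called first, only, known or untested is meant among the compounds shown, and "the series" means these compounds.

Among the compounds with values here, in an ADME assay (liver) for metabolic stability, with Liver microsome (Rattus norvegicus) as the target, using microsomes and NADPH, with a stated time of 30 min, tested at 1 uM (on this read-out lower numbers stand for slow clearance and higher numbers for fast clearance), compound 2 (`Nc1ccc(S(=O)(=O)N2CCN(c3ncc(C(O)(C(F)(F)F)C(F)(F)F)cc3-c3cccc(F)c3)CC2)cn1`) gives 52 mL.min-1.g-1, the lower of the two numbers measured so far, while compound 1 (`Cc1csc(-c2cc(C(O)(C(F)(F)F)C(F)(F)F)cnc2N2CCN(S(=O)(=O)c3ccc(N)nc3)CC2)c1`) gives 399 mL.min-1.g-1. Compound 3 (`Nc1ccc(S(=O)(=O)N2CCN(c3ncc(C(O)(C(F)(F)F)C(F)(F)F)cc3-c3ccncc3)CC2)cn1`) differs from compound 2 in one place: pyridin-4-yl in place of 3-fluorophenyl on an aromatic carbon. Within the data shown here, one measured step bears on this place: a 7.7-fold lower number from compound 1 to compound 2 (0.88 log units; beyond the scatter), a modest change beyond the scatter, when 3-fluorophenyl took the place of 4-methylthiophen-2-yl. Among the measured compounds shown here, that step shows that the group here can move this assay, but it is a different exchange, and no pyridin-4-yl compound has yet been measured. The direction is therefore a tentative judgement. The expected change is a modest one toward a lower number, a 1.7-fold lower number from compound 2 to compound 3 (0.24 log units; within the scatter). Compound 3 is estimated at 30 mL.min-1.g-1, with an expected range from 11 mL.min-1.g-1 to 85 mL.min-1.g-1.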

Compound 3, intrinsic clearance in microsomes: 31 mL.min-1.g-1
The estimate for compound 3 lay 1.0-fold (0.01 log units) below the measured number; low and high end bracket the measured number.
By their numbers in this assay, from the lowest: compounds 3 and 2 (each within the scatter of the next); then compound 1.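

In this assay, pyridin-4-yl in place of 3-fluorophenyl, on the aromatic carbon ortho to a large group, gives a step that stays inside the scatter (a 1.7-fold lower number from compound 2 to compound 3 (0.22 log units; within the scatter)), so these two six-membered aromatic rings cannot be told apart at this position, even though the entering ring brings a ring nitrogen and a hydrogen-bond acceptor. Pyridin-4-yl in place of 4-methylthiophen-2-yl gives a large step beyond the scatter (a 13-fold lower number from compound 1 to compound 3 (1.11 log units; beyond the scatter)), so among these three compounds both six-membered aromatic rings stand clearly apart from compound 1. Nothing available explains these numbers.

From the compounds shown here alone, it remains open whether the high number of compound 1 follows the thiophene ring or its methyl group, which plain thiophen-2-yl would separate. Going by these compounds, whether a non-aromatic group such as morpholine or a carboxylic acid at this position would hold the low numbers also stays open.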